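Extending a Chain on Two Related Cores

This account rests on a few compounds, and the source may have more. Where it says the series, first, only, none or still open, it means among the compounds named here.

Compound 2 `CCc1csc(CN[C@@H]2C[C@H]3C[C@@H]([C@H]2C)C3(C)C)c1` and compound 3 `CCc1ccsc1CN[C@@H]1C[C@H]2C[C@@H]([C@H]1C)C2(C)C` are built from the same atoms joined differently; the difference between the two cores is not broken down here. In an ADME assay on MDCK cells (Canis lupus familiaris) for cytotoxicity, read by microscopy, with a stated time of 48 h (a lower number here means that less compound is tolerated, a higher number that more compound is tolerated), compound 2 gives 25000 nM, and compound 3 gives 25000 nM, the same number at the digits reported, so the two are level and the pair shows no change. Compound 1 `CCCCc1csc(CN[C@@H]2C[C@H]3C[C@@H]([C@H]2C)C3(C)C)c1` is reached from compound 2 through the change (ethyl in place of hydrogen on a saturated chain carbon, two bonds along the chain from an aromatic carbon). In this assay compound 1 gives 12500 nM, and the step of a 2.0-fold lower number from compound 2 to compound 1 (0.30 log units; within the scatter) stays within the scatter of repeated measurements, so a single pair cannot show whether the longer chain changes how much compound the cells tolerate.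

Compound 4 `CCCCc1ccsc1CN[C@@H]1C[C@H]2C[C@@H]([C@H]1C)C2(C)C` has not yet been measured. It differs from compound 3 by ethyl in place of hydrogen on a saturated chain carbon, two bonds along the chain from an aromatic carbon, which is the same change as the one from compound 2 to compound 1, made on the other core; across the compounds shown this change appears in both pairs. For compound 4 the expected step is a 2.0-fold lower number from compound 3 to compound 4 (0.30 log units; within the scatter), matching the earlier one in direction and size, because the step of a 2.0-fold lower number from compound 2 to compound 1 (0.30 log units; within the scatter) was small and the two cores gave the same number before the change. Compound 4 is therefore expected to give about 12500 nM in this assay. For compound 4 the estimated range runs from 6250 nM to 25000 nM.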

Compound 4, minimum cytotoxic concentration: 25000 nM
Compound 4: middle estimate off by 2.0-fold (0.30 log units), on the low side; the range from low to high includes it.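

On the core of compound 3, ethyl in place of hydrogen on a saturated chain carbon, two bonds along the chain from an aromatic carbon, gives no change at the digits printed from compound 3 to compound 4 (within the scatter) in this assay. Set beside the same change on the core of compound 1, the two steps cannot be told apart: the same change on two cores in this assay, a 2.0-fold lower number (0.30 log units; within the scatter) from compound 2 to compound 1 and no change at the digits printed (within the scatter) from compound 3 to compound 4, 2.0-fold (0.30 log units) apart, within the scatter of two such steps. This shows that, in these two pairs, lengthening ethyl to butyl has no readable effect on how much compound the cells tolerate on either core, so nothing here separates one core from the other; it does not show that the two cores respond identically, since a real but small effect could lie hidden within the scatter, and it gives the change no reliable direction.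

The compounds shown leave open whether a chain longer than butyl, or an amine or a carboxylic acid at the end of the chain in this place, would produce a step beyond the scatter in this assay. They also leave open whether the same ethyl-for-hydrogen change would behave in this way on any core other than these two.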